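The compounds below may be only part of what the source reports. "The series", "measured", "known", "first", "only" and "open" are said of these compounds alone.

Compound 1 `Cn1c(-c2ccc(NC(=O)CSc3nc4ccccc4s3)cc2)nc(-c2ccccc2)c1-c1ccccc1` is one of three related compounds tested in a functional assay on MCF7 cells (Homo sapiens) for cytotoxicity, read by MTT assay, with a stated time of 24 h, tested at 16 ug/mL (a lower number here means a weaker effect, a higher number a stronger effect of the compound at the concentration tested), where compound 1 gives 50.3%. It stands second highest of the three numbers, though its gap to compound 3 lies within the usual scatter. Compound 2 `Cn1nnnc1SCC(=O)Nc1ccc(-c2nc(-c3ccccc3)c(-c3ccccc3)n2C)cc1` gives 63.7%, a step of a number 13.4 percentage points higher from compound 1 to compound 2 (beyond the scatter), while compound 3 `Cn1c(-c2ccc(NC(=O)CSC3=NCCS3)cc2)nc(-c2ccccc2)c1-c1ccccc1` gives 41.8%, a step of a number 8.5 percentage points lower from compound 1 to compound 3 (within the scatter). Compound 4 `Cn1c(-c2ccc(NC(=O)CN3CCN(c4ccccc4)CC3)cc2)nc(-c2ccccc2)c1-c1ccccc1` has not yet been measured; it differs from compound 1 in one place: 4-phenylpiperazin-1-yl in place of (1,3-benzothiazol-2-yl)sulfanyl on a saturated chain carbon bound to a carbonyl carbon. Both measured steps also exchanged the group carried by that sulfur, and neither moved the read-out more than modestly. The change to compound 4 goes further, removing the sulfur as well, and the expected step is estimated as a number 0.3 percentage points lower from compound 1 to compound 4 (within the scatter), with no clear direction. Compound 4 is therefore expected to give 50%, between 30% and 70%.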

Compound 4, a percentage reported as activity, at one concentration (the size of the read-out at that concentration, not a potency): 59.6%
The estimate for compound 4 lay 9.6 percentage points below the measured number; low and high end bracket the measured number.
By their numbers in this assay, from the lowest: compounds 3, 1, 4 and 2 (each within the scatter of the next, the first and the last beyond it).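

In this assay the sulfur on the saturated chain carbon bound to a carbonyl carbon is not required for this level of read-out, since 4-phenylpiperazin-1-yl has none and gives a number 9.3 percentage points higher from compound 1 to compound 4 (within the scatter) and a number 4.1 percentage points lower from compound 2 to compound 4 (within the scatter). Only compound 3 stands apart, with a number 17.8 percentage points higher from compound 3 to compound 4 (beyond the scatter). This place therefore tolerates a ring joined through nitrogen as well as the sulfur-linked groups of compound 1 and compound 2.

Nothing available explains these differences. From the compounds shown here alone, whether a smaller amine such as morpholin-4-yl or a carboxylic acid would hold the read-out remains open.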